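A Larger Charged Group Replaces Hydroxymethyl

A few compounds are considered here, and "the series" means these few. Any claim that something is new, unique, unknown or untested is made for them only; others in the source may bear on it.

In a physicochemical assay for metabolic stability, read by HPLC and mass spectrometry, in phosphate buffer, at 37 degrees C, at pH 7.4 (a higher number here means that the compound lasts longer, a lower number that the compound disappears faster), compound 3 (`CC(C)(O/N=C(\C(=O)N[C@@H]1C(=O)N(S(=O)(=O)O)[C@@H]1Cn1cc(CO)nn1)c1csc(N)n1)C(=O)O`) reads > 37 h, which is a limit and not a number. Compound 1 (`CC(C)(O/N=C(\C(=O)N[C@@H]1C(=O)N(S(=O)(=O)O)[C@@H]1CN1CCCC1=O)c1csc(N)n1)C(=O)O`) reads > 1000 h, which is also a limit. Among the measured compounds shown here, compound 2 (`CC(C)(O/N=C(\C(=O)N[C@@H]1C(=O)N(S(=O)(=O)O)[C@@H]1Cn1ccnn1)c1csc(N)n1)C(=O)O`) gives 257 h, the one true number among the three.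

The next compound, compound 4 (`CC(C)(O/N=C(\C(=O)N[C@@H]1C(=O)N(S(=O)(=O)O)[C@@H]1Cn1cc(NC(=O)C[N+](C)(C)C)nn1)c1csc(N)n1)C(=O)O`), keeps the shared core but exchanges the hydroxymethyl of compound 3, on an aromatic carbon, for a group with net charge +1: a group of 8 heavy atoms (5 carbon, 2 nitrogen, 1 oxygen; no ring) in place of a group of 2 heavy atoms (1 carbon, 1 oxygen; no ring), on an aromatic carbon.

For the measured compounds named here, two measured steps bear on this change. Going by the values given here, the exchange of 2-oxopyrrolidin-1-yl for 1H-1,2,3-triazol-1-yl is an at least 3.8-fold lower number from compound 1 to compound 2 (0.59 log units; beyond the scatter), and it is the only step whose size can be read. The step closest to the present change, hydroxymethyl in place of hydrogen on an aromatic carbon, is a step that the limit leaves unreadable from compound 2 to compound 3, so it gives no size to carry forward.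

Among the compounds with values here, the expectation therefore rests on compound 2, at 257 h, as the one number available, and is set somewhat lower. Taken from a limit, the expected step is only rough: a step that the limit leaves unreadable from compound 3 to compound 4. For compound 4 the estimate is 100 h, with an expected range from 30 h to 350 h.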

Compound 4, half-life: > 37 h
Compound 4 was reported as a limit; the forecaster's own chance of this, stated with the estimate: 25%; the middle value is on the limit's open side.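

In this assay compound 4 reads > 37 h, which is a limit, and neither its step from compound 3 nor its step from compound 2 can be read. The compounds shown leave open how long compound 3 and compound 4 actually last, and whether the group with net charge +1 shifts the half-life relative to hydroxymethyl at all.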